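Replacing the iodo group of compound 2 with hydrogen

This account rests on a few compounds, and the source may have more. Where it says the series, first, only, none or still open, it means among the compounds named here.

Compound 1 `COc1ccccc1-c1cnc(OCCCc2ccccc2)n1C`: 3000 nM
Compound 2 `C=CCCCCOc1ncc(I)n1C`: > 100000 nM

Both results come from a functional assay on T98G cells (Homo sapiens) for inhibition, read by colorimetric assay and MTT assay, with a stated time of 72 h; a lower number here means a stronger inhibitor, a higher number a weaker inhibitor. Compound 1 gives a true number, 3000 nM. For compound 2 the result is > 100000 nM, which is a limit of the assay and not a measured number. Compound 2 therefore stands at the limit of > 100000 nM in this assay, at which 1 of the 2 values shown sits.

The next compound, compound 3 `C=CCCCCOc1nccn1C`, differs from compound 2 in one place: hydrogen in place of iodo on an aromatic carbon. Going by the values given here, no measured pair shows what such a swap does, so there is no direct precedent for the size of the step. Among the compounds with values here, the only anchor is compound 2, with its limit of > 100000 nM. With so little to go on, no step beyond the scatter is expected in this assay, and neither direction is favoured. The expected step is a number no higher from compound 2 to compound 3 (the limit leaves the size open). The result may well arrive as a limit again. For compound 3 the estimated value is 100000 nM, with an expected range from 30000 nM to 300000 nM.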

Compound 3, half-maximal inhibitory concentration: > 100000 nM
Compound 3: a limit, no number; the forecaster's own chance of this, stated with the estimate: 70%; the middle value lies on the limit itself.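

In this assay compound 3 gives > 100000 nM, which is a limit of the assay and not a number. Compound 2 also stands at a limit, so no step can be read between compound 2 and compound 3: the limit of > 100000 nM in this assay, at which 2 of the 3 values shown sit.

The compounds shown leave open what hydrogen in place of iodo on an aromatic carbon does to inhibition.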